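Swapping 4-fluorophenyl for 2-chlorophenyl: a small step expected

A few compounds are considered here, and "the series" means these few. Any claim that something is new, unique, unknown or untested is made for them only; others in the source may bear on it.

In a functional assay on MCF7 cells (Homo sapiens) for antiproliferative activity, read by MTT assay, with a stated time of 72 h (a higher number here means a weaker inhibitor, a lower number a stronger inhibitor), compound 1 `COc1cc(/C=C/c2ccc(C3=C(c4ccc(O)cc4)C4CC(S(=O)(=O)Oc5ccc(Br)cc5)C3O4)cc2)cc(OC)c1` shows > 100000 nM, which is a limit of the assay and not a number. Compound 2 `O=S(=O)(Oc1ccc(Br)cc1)C1CC2OC1C(c1ccc(/C=C/c3cc(O)cc(O)c3)cc1)=C2c1ccc(O)cc1` gives 16900 nM. Placing 3,5-dihydroxyphenyl where 3,5-dimethoxyphenyl stood brings an at least 5.9-fold lower number from compound 1 to compound 2 (0.77 log units; beyond the scatter). Compound 3 `O=S(=O)(Oc1ccc(F)cc1)C1CC2OC1C(c1ccc(/C=C/c3cc(O)cc(O)c3)cc1)=C2c1ccc(O)cc1` gives 13100 nM, which stands level with compound 2 within the scatter.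

The next molecule is compound 4 `O=S(=O)(Oc1ccccc1Cl)C1CC2OC1C(c1ccc(/C=C/c3cc(O)cc(O)c3)cc1)=C2c1ccc(O)cc1`. It has 2-chlorophenyl in place of 4-fluorophenyl, on an oxygen whose other neighbour is the sulfonyl sulfur (2-chlorophenyl in place of 4-fluorophenyl on an oxygen). The nearest guide is the swap of fluoro for bromo on the same aromatic group, which gave a 1.3-fold lower number from compound 2 to compound 3 (0.11 log units; within the scatter) and stayed within the scatter. The larger step concerns a different group, so it says little about this change. Among the measured compounds shown here, no measured compound yet carries a 2-chlorophenyl group, so the halogen's new place remains untested and the range must stay wide.

The estimated step is a 1.1-fold higher number from compound 3 to compound 4 (0.03 log units; within the scatter), which is expected to stay within the scatter. Compound 4 is expected at 14000 nM. Its estimated range runs from 6000 nM to 35000 nM.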

Compound 4, half-maximal inhibitory concentration: 40400 nM
Compound 4: the middle estimate sits 2.9-fold (0.46 log units) below what was measured; measured number above the stated range.
By their numbers in this assay, from the lowest: compounds 3 and 2 (each within the scatter of the next); then compound 4. At a limit, above all of these: compound 1.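

In this assay the aryl group on the oxygen bound to the sulfonyl sulfur first looked free to vary, since exchanging 4-bromophenyl for 4-fluorophenyl gave only a 1.3-fold lower number from compound 2 to compound 3 (0.11 log units; within the scatter) and so no real difference. The 2-chlorophenyl group breaks that picture: it brings a 3.1-fold higher number from compound 3 to compound 4 (0.49 log units; beyond the scatter) and also a 2.4-fold higher number from compound 2 to compound 4 (0.38 log units; beyond the scatter) as a second, matching comparison, both modest but beyond the scatter. Among the compounds shown here, this position therefore does respond to what is placed on it, though the only measurement offered as evidence has no bearing on why this group raises the number.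

The step from compound 3 to compound 4 changes the halogen and its place on the ring together, so these compounds cannot tell whether the chlorine itself or its new place matters more. Also open, as far as these compounds go, is how this position would respond to a phenyl ring carrying no halogen, or to a ring bearing a methoxy group, an amine or a carboxylic acid.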